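Chloro in Place of Fluoro: From Compound 2 to Compound 3

The compounds below may be only part of what the source reports. "The series", "measured", "known", "first", "only" and "open" are said of these compounds alone.

The set holds compound 1 `Cc1ccc(C(=O)N/N=C/c2cc(I)cc(I)c2O)cc1` and compound 2 `O=C(NNCc1cc(I)cc(I)c1O)c1ccc(F)cc1`. In a functional assay on HepG2 cells (Homo sapiens) for cytotoxicity, with a stated time of 24 h (on this read-out lower numbers stand for stronger inhibition and higher numbers for weaker inhibition), compound 1 gives only a limit of > 25000 nM, not a number. In this assay, among the compounds with values here, compound 2 gives 52200 nM, the only numerical value shown. The other entry is a limit, (the limit of > 25000 nM in this assay, at which 1 of the 2 values shown sits). Compound 3 `O=C(NNCc1cc(I)cc(I)c1O)c1ccc(Cl)cc1` differs from compound 2 by chloro in place of fluoro on an aromatic carbon. No measured step of this kind is shown. The step from compound 2 to compound 3 is expected to stay within the usual scatter, a 1.2-fold lower number from compound 2 to compound 3 (0.09 log units; within the scatter). Compound 3 is therefore estimated at 42000 nM, with a range from 18000 nM to 100000 nM.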

Compound 3, half-maximal inhibitory concentration: 52200 nM
Compound 3: middle estimate off by 1.2-fold (0.09 log units), on the low side, and the stated range covers the measured number.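

Going from 4-fluorophenyl to 4-chlorophenyl gives the only measured step at this position: in this assay the change shows no change at the digits printed from compound 2 to compound 3 (within the scatter) on this aromatic carbon. Between these two compounds, the read-out therefore does not distinguish fluoro from chloro here. Nothing shown explains this result.

Still open, on these data alone, is whether an amine, a carboxylic acid or a longer chain at this carbon would move the read-out beyond the scatter. Within the data shown here, compound 1 gives only a limit (> 25000 nM) and differs from the other compounds in more than one place, so no step to it can be read.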